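The source may hold more compounds than are shown below. What is called first, only, known or untested is meant among the compounds shown, and "the series" means these compounds.

Compound 1 `O=C1c2sccc2N(Cc2ccccc2Br)S(=O)(=O)N1Cc1ccccc1` heads these notes. In an ADME assay on MT4 cells (Homo sapiens) for cytotoxicity, read by MTT assay, with a stated time of 4 days (on this read-out higher numbers stand for lower toxicity in this test and lower numbers for higher toxicity in this test), compound 1 gives > 270000 nM, which is a limit of the assay rather than a number. Compound 2 `O=C1c2sccc2N(Cc2cccc(Cl)c2)S(=O)(=O)N1Cc1ccccc1` in this assay gives > 298000 nM, likewise a limit. Among the compounds with values here, the one measured step, a step that the two limits leave unreadable from compound 1 to compound 2, therefore carries no readable size or direction, both of its ends resting at limits, as the limit of > 270000 nM in this assay, at which 1 of the 2 values shown sits, and the limit of > 298000 nM in this assay, at which 1 of the 2 values shown sits, record. Compound 3 `O=C1c2sccc2N(Cc2ccc([N+](=O)[O-])cc2)S(=O)(=O)N1Cc1ccccc1` awaits this assay; its change from compound 1 is 4-nitrophenyl in place of 2-bromophenyl on a saturated chain carbon bound to a sulfonamide nitrogen in a ring. Within the data shown here, the single measured step concerns a different group at the same place and yields no size, so nothing here favours a step beyond the scatter in either direction, and a further limit is the likeliest outcome. Compound 3 is accordingly expected at about 270000 nM, within 100000 nM to 450000 nM. The step of a number no higher from compound 1 to compound 3 (the limit leaves the size open) is the estimated consequence, most probably reported again only as a limit.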

Compound 3, half-maximal cytotoxic concentration: 268000 nM
Estimate against measurement, compound 3: 1.0-fold (0.00 log units) above; low and high end bracket the measured number.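

In this assay, within the data shown here, compound 3, with 4-nitrophenyl on a saturated chain carbon bound to a sulfonamide nitrogen in a ring, gives 268000 nM, the first value at this place that is a number and not a limit of the assay. The change from 2-bromophenyl to 4-nitrophenyl gives a number no higher from compound 1 to compound 3 (the limit leaves the size open). The change from 3-chlorophenyl to 4-nitrophenyl gives an at least 1.1-fold lower number from compound 2 to compound 3 (0.04 log units; that floor lies within the scatter), so a floor is all that can be stated, and no step beyond the scatter is shown at this place. The sizes of the steps from compound 1 cannot be read, its value being a limit of the assay: the limit of > 270000 nM in this assay, at which 1 of the 3 values shown sits.

On these data alone, how far the number in this assay would move with an amine or a carboxylic acid on the phenyl ring stays open. So does the effect of a longer chain between that ring and the sulfonamide nitrogen.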